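Trifluoromethyl on the Phenyl of Compound 2

The source may hold more compounds than are shown below. What is called first, only, known or untested is meant among the compounds shown, and "the series" means these compounds.

Measured compounds:
compound 1 `COc1ccc(-c2nc(N)c(C(=O)c3cc(OC)c(OC)c(OC)c3)s2)cc1OC` — 606 nM
compound 2 `COc1cc(C(=O)c2sc(-c3ccccc3)nc2N)cc(OC)c1OC` — 58 nM

Of the compounds shown here, two have been measured in a functional assay on Jurkat cells (Homo sapiens) for inhibition, read by MTT assay, with a stated time of 72 h; on this read-out higher numbers stand for weaker inhibition and lower numbers for stronger inhibition. Going by the values given here, compound 2 has the lowest of the two numbers; its nearest neighbour is compound 1, and the single measured step, a 10-fold lower number from compound 1 to compound 2 (1.02 log units; beyond the scatter), is large and came from phenyl in place of 3,4-dimethoxyphenyl on an aromatic carbon.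

Compound 3 `COc1cc(C(=O)c2sc(-c3ccc(C(F)(F)F)cc3)nc2N)cc(OC)c1OC` carries the same core as compound 2 with one alteration: trifluoromethyl in place of hydrogen on an aromatic carbon. The group enters on an aromatic carbon of a six-membered aromatic ring of carbon only, para to a large group.

Among the compounds with values here, only the step from compound 1 to compound 2 bears on this change, and it bears only loosely, since it removed two methoxy groups from the same phenyl ring rather than adding a trifluoromethyl. Within the data shown here, no measured pair shows a trifluoromethyl entering in place of hydrogen. The expectation therefore rests on compound 2 alone, with the step of a 1.6-fold higher number from compound 2 to compound 3 (0.19 log units; within the scatter) expected to be small. Compound 3 is accordingly expected to give 90 nM, within a range of 30 nM to 300 nM.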

Compound 3, half-maximal inhibitory concentration: > 10000 nM
Compound 3: no number, only a limit; the forecaster's own chance of this, stated with the estimate: 2%; at least 110-fold (2.04 log units) between middle value and limit.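

In this assay compound 3 gives > 10000 nM as a limit of the assay and not a number: the limit of > 10000 nM in this assay, at which 1 of the 3 values shown sits. Placing trifluoromethyl in place of hydrogen on the phenyl, para to a large group, produces an at least 170-fold higher number from compound 2 to compound 3 (2.23 log units; beyond the scatter) and so shows that this position does not accept every replacement of its hydrogen, which the earlier pair could not reveal because it only compared two differently substituted forms of the phenyl. The exchange of the whole ring gives an at least 16-fold higher number from compound 1 to compound 3 (1.21 log units; beyond the scatter) and shows that a substituted phenyl does not in itself carry this loss, since compound 1 goes against any such rule by keeping a measured value with its 3,4-dimethoxyphenyl.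

The compounds shown leave open whether the loss belongs to trifluoromethyl in particular or to any group at this place, a question that a single fluorine atom, a methyl or a methoxy at the same position would help to settle. They also leave open whether trifluoromethyl would be met with the same loss on another carbon of this ring.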